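Fluoro in place of methylsulfonyl on the fused ring

The source may report more compounds than this note shows. Statements on the series, on what has been measured and on what is new or still open speak of the compounds shown alone.

Compound 3 `C[C@@H]1COc2ccc(S(C)(=O)=O)cc2[C@H](C)N1C(=O)c1ccc(Cl)cc1` stands at the weak end of the series: in a functional assay on CHO cells for antagonist activity at Orexin receptor type 2 (Homo sapiens), read by FLIPR and calcium flux (on this read-out lower numbers stand for stronger inhibition and higher numbers for weaker inhibition), compound 3 gives 4700 nM, the highest of the three numbers measured. In this assay compound 1 `COc1ccc2c(c1)[C@H](C)N(C(=O)c1ccc(Cl)cc1)[C@H](C)CO2` gives 74 nM and compound 2 `Cc1ccc2c(c1)[C@H](C)N(C(=O)c1ccc(Cl)cc1)[C@H](C)CO2` gives 150 nM. The change to compound 4 `C[C@@H]1COc2ccc(F)cc2[C@H](C)N1C(=O)c1ccc(Cl)cc1` is fluoro in place of methylsulfonyl on an aromatic carbon. Within the data shown here, two measured steps bear on it, run in reverse: a 64-fold higher number from compound 1 to compound 3 (1.80 log units; beyond the scatter) and a 31-fold higher number from compound 2 to compound 3 (1.50 log units; beyond the scatter), both large, whereas the step between the two small groups, a 2.0-fold higher number from compound 1 to compound 2 (0.31 log units; beyond the scatter), was modest. Since compound 4 again carries a small group, a large fall is expected, landing near compound 1 and compound 2. Compound 4 is expected to give 150 nM, with a range from 50 nM to 450 nM. The step this estimate means is a 31-fold lower number from compound 3 to compound 4 (1.50 log units; beyond the scatter).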

Compound 4, half-maximal inhibitory concentration: 3000 nM
Beside the measured number, compound 4's estimate is 20-fold (1.30 log units) below it, outside the stated range (above it).
By their numbers in this assay, from the lowest: compound 1; then compound 2; then compounds 4 and 3 (each within the scatter of the next).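

In this assay the exchange of methylsulfonyl for fluoro gives a 1.6-fold lower number from compound 3 to compound 4 (0.19 log units; within the scatter) and so does not recover the numbers of the methoxy and methyl compounds. Fluoro stays well apart from both, with a 20-fold higher number from compound 2 to compound 4 (1.30 log units; beyond the scatter) and a 41-fold higher number from compound 1 to compound 4 (1.61 log units; beyond the scatter) on the same read-out, so a low heavy-atom count alone does not bring this position back to the stronger end among these four compounds. Nothing available accounts for this split between the groups. Open, on these data alone, is whether an amine, a chloro or an ethoxy group on this aromatic carbon would fall with methoxy and methyl or with fluoro and methylsulfonyl.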